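Pyridin-4-yl in place of pyridin-3-yl on compound 2

This account rests on a few compounds, and the source may have more. Where it says the series, first, only, none or still open, it means among the compounds named here.

In a functional assay on HepG2 cells (Homo sapiens) for cytotoxicity, read by MTT assay, with a stated time of 24 h (a higher number here means a weaker inhibitor, a lower number a stronger inhibitor), compound 1 `O=C1/C(=C/c2cccnc2)CN(S(=O)(=O)c2ccc([N+](=O)[O-])cc2)C/C1=C\c1ccccc1C(F)(F)F` gives 9370 nM and compound 2 `O=C1/C(=C/c2cccnc2)CN(S(=O)(=O)c2ccc(Cl)cc2)C/C1=C\c1ccccc1C(F)(F)F` gives 3620 nM while compound 3 `O=C1/C(=C/c2cccnc2)CN(S(=O)(=O)c2ccc(Br)cc2)C/C1=C\c1ccccc1C(F)(F)F` gives 2730 nM on the same scale. Compound 2 thus stands with compound 3 at the low end of these numbers: a 1.3-fold lower number from compound 2 to compound 3 (0.12 log units; within the scatter) is a step within the scatter, whereas a 2.6-fold lower number from compound 1 to compound 2 (0.41 log units; beyond the scatter) is a step beyond it.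

Compound 4 `O=C1/C(=C/c2ccncc2)CN(S(=O)(=O)c2ccc(Cl)cc2)C/C1=C\c1ccccc1C(F)(F)F` differs from compound 2 at one place, a double-bonded chain carbon bound to a double-bonded ring carbon, where pyridin-4-yl stands in place of pyridin-3-yl pyridin-4-yl in place of pyridin-3-yl on a double-bonded chain carbon bound to a double-bonded ring carbon and nothing else changes. Among the measured compounds shown here, none of the measured steps touches this place. All of them exchange nitro, chloro or bromo on an aromatic carbon, and the widest, a 3.4-fold lower number from compound 1 to compound 3 (0.54 log units; beyond the scatter), is only modest. They give no direction for the new change and show only the size that single exchanges reached in this small set.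

Compound 2 at 3620 nM is therefore the best guide, and no step beyond the scatter is expected in this assay in either direction. The estimated change is a 1.0-fold lower number from compound 2 to compound 4 (0.01 log units; within the scatter) and stays inside the scatter. Compound 4 is expected at 3500 nM with an estimated range of 1500 nM to 8000 nM around that middle.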

Compound 4, half-maximal inhibitory concentration: 7190 nM
Compound 4: the middle estimate sits 2.1-fold (0.31 log units) below what was measured; the measured number falls inside the stated range.
By their numbers in this assay, from the lowest: compounds 3, 2, 4 and 1 (each within the scatter of the next, the first and the last beyond it).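

In this assay, the double-bonded chain carbon bound to a double-bonded ring carbon now has a measured step of its own, a 2.0-fold higher number from compound 2 to compound 4 (0.30 log units; within the scatter), whereas every earlier step exchanged a group on an aromatic carbon elsewhere in the molecule. Pyridin-4-yl and pyridin-3-yl have the same atoms and the same counts of donors and acceptors, and this exchange stays within the scatter, unlike a 2.6-fold lower number from compound 1 to compound 2 (0.41 log units; beyond the scatter), which lies beyond it, so this one pair sets no firm order between the two pyridine attachments. Nothing at hand accounts for the size of the step at this position.

Going by these compounds, the exchange is read only on the chloro compounds, so it remains open whether pyridin-4-yl in place of pyridin-3-yl would give a step of similar size alongside the nitro group of compound 1 or the bromo group of compound 3. Also open is where pyridin-2-yl or a plain phenyl ring at this same place would fall on this scale, since the compounds shown carry only the two pyridine attachments there.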